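The source may report more compounds than this note shows. Statements on the series, on what has been measured and on what is new or still open speak of the compounds shown alone.

Compound 1 `CC(C)c1ccc2c(CCCCS(=O)(=O)Nc3ccccc3)cc(C(=O)O)c-2cc1` and compound 2 `CC(C)c1ccc2c(CCCCS(=O)(=O)Nc3ccc(Cl)cc3)cc(C(=O)O)c-2cc1` share one core, while compound 3 `CC(C)c1ccc2c(CCCC(=O)NS(=O)(=O)c3ccccc3)cc(S(=O)(=O)O)c-2cc1` and compound 4 `CC(C)c1ccc2c(CCCC(=O)NS(=O)(=O)c3ccc(Cl)cc3)cc(S(=O)(=O)O)c-2cc1` share another; the difference between the two cores is not broken down here. In a functional assay on thoracic aorta for antagonist activity at thromboxane A2 receptor (Rattus norvegicus) (a lower number here means a stronger inhibitor, a higher number a weaker inhibitor), compound 1 gives 8700 nM, and compound 2 gives 2600 nM. The change between them, (chloro in place of hydrogen on an aromatic carbon), produced a 3.3-fold lower number from compound 1 to compound 2 (0.52 log units; beyond the scatter). In this assay compound 3 gives 65000 nM, the highest number of the three measured. Compound 4 carries the same change on its own core, (chloro in place of hydrogen on an aromatic carbon), at a place described in the same words as before. A step of similar size is expected here, a 3.3-fold lower number from compound 3 to compound 4 (0.51 log units; beyond the scatter), because the earlier step of a 3.3-fold lower number from compound 1 to compound 2 (0.52 log units; beyond the scatter) was modest and the change is the same. On that basis compound 4 is estimated at 20000 nM in this assay, with a likely span from 8000 nM to 50000 nM.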

Compound 4, half-maximal inhibitory concentration: 54000 nM
The estimate for compound 4 lay 2.7-fold (0.43 log units) below the measured number; the whole stated range lies below it.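

On the core of compound 3, chloro in place of hydrogen gave a 1.2-fold lower number from compound 3 to compound 4 (0.08 log units; within the scatter) in this assay, so the change has no readable effect there. Set beside the earlier step, the same change did not carry over at the same size from one core to the other: the same change on two cores in this assay, a 3.3-fold lower number (0.52 log units; beyond the scatter) from compound 1 to compound 2 and a 1.2-fold lower number (0.08 log units; within the scatter) from compound 3 to compound 4, 2.8-fold (0.44 log units) apart, beyond the scatter of two such steps This rests on a single change on two cores; it gives no general rule and does not show which difference between the cores matters.

The compounds shown leave open whether a bromo or methoxy group in place of the chloro would behave the same way on each core. They also leave open how a core pairing the carboxylic acid of compound 1 with the chain of compound 3 would respond.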